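Thiophen-2-yl to thiophen-3-yl: working notes

The source may report more compounds than this note shows. Statements on the series, on what has been measured and on what is new or still open speak of the compounds shown alone.

Compound 1 `CN(C)c1ccc(Nc2nccc(-c3ccsc3)n2)cc1`: 2100 nM
Compound 2 `COc1cccc(Nc2nccc(-c3cccs3)n2)c1`: 900 nM
Compound 3 `CN(C)c1ccc(Nc2nccc(-c3cccs3)n2)cc1`: 900 nM

All three were measured in a functional assay for inhibition, with Homo sapiens as the target; a higher number here means a weaker inhibitor, a lower number a stronger inhibitor. Compound 2 and compound 3 give the same number at the digits shown, within the scatter. Within the data shown here, the one counted step, a 2.3-fold higher number from compound 3 to compound 1 (0.37 log units; beyond the scatter), corresponds to thiophen-3-yl in place of thiophen-2-yl on an aromatic carbon. The cores of compound 2 and compound 3 differ; that difference is not broken down here.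

Compound 4 `COc1cccc(Nc2nccc(-c3ccsc3)n2)c1` has not been measured. It relates to compound 2 by thiophen-3-yl in place of thiophen-2-yl on an aromatic carbon, the same kind of change as that between compound 3 and compound 1, though the place lines differ: meta to a group of 9 heavy atoms in compound 2, meta to a large group in compound 3.

In this assay a step of similar size is expected, resting on a 2.3-fold higher number from compound 3 to compound 1 (0.37 log units; beyond the scatter), namely a 2.3-fold higher number from compound 2 to compound 4 (0.37 log units; beyond the scatter). Compound 4 is therefore estimated at 2100 nM, with a range from 1000 nM to 4500 nM.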

Compound 4, half-maximal inhibitory concentration: 1800 nM
For compound 4 the middle estimate is 1.2-fold (0.07 log units) above the measured one, and the stated range covers the measured number.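

In this assay, thiophen-3-yl in place of thiophen-2-yl gives a 2.0-fold higher number from compound 2 to compound 4 (0.30 log units; within the scatter) on the core of compound 2. Set beside the earlier step, the change carries across these two cores with no difference in size that can be told apart: the same change on two cores in this assay, a 2.3-fold higher number (0.37 log units; beyond the scatter) from compound 3 to compound 1 and a 2.0-fold higher number (0.30 log units; within the scatter) from compound 2 to compound 4, 1.2-fold (0.07 log units) apart, within the scatter of two such steps. This rests on a single pair on each core, and the newer step itself lies within the scatter, so it does not show that the change would keep its size on any further core.

The compounds shown leave open how other groups at this place would read, such as furan-2-yl or phenyl. Also open, on these data alone, is whether the step holds on a core carrying a carboxylic acid in place of the methoxy or dimethylamino group.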